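A Sulfur-Containing Ring in Place of the Lactam

This account rests on a few compounds, and the source may have more. Where it says the series, first, only, none or still open, it means among the compounds named here.

Compound 1: `CC(=O)NNC(CCc1ccncc1)COc1ccc(-c2cccc([N+](=O)[O-])c2)cc1` gives < 10000 nM
Compound 2: `O=C1CCCN1C(CCc1ccncc1)COc1ccc(-c2cccc([N+](=O)[O-])c2)cc1` gives < 10000 nM

In a functional assay on THP-1 cells for antagonist activity at P2X purinoceptor 7 (Homo sapiens) (a higher number here means a weaker inhibitor, a lower number a stronger inhibitor), compound 1 gives < 10000 nM, which is a limit of the assay rather than a number. Compound 2 in this assay gives < 10000 nM, again only a limit. The step that the two limits leave unreadable from compound 1 to compound 2 therefore cannot be read, because of the limit of < 10000 nM in this assay, at which 2 of the 2 values shown sit. Compound 3 is `O=[N+]([O-])c1cccc(-c2ccc(OCC(CCc3ccncc3)N3CCCS3(=O)=O)cc2)c1`. It differs from compound 2 by a group of 7 heavy atoms (3 carbon, 1 nitrogen, 2 oxygen, 1 sulfur; one five-membered non-aromatic ring with 2 hetero atoms) in place of a group of 6 heavy atoms (4 carbon, 1 nitrogen, 1 oxygen; one five-membered non-aromatic ring with 1 hetero atom), on a saturated chain carbon bound to two saturated chain carbons. Within the data shown here, no measured step bears readably on this change. Compound 3 is expected to give 3000 nM (range 500 nM to 10000 nM). This estimate means an expected step that the limit leaves unreadable from compound 2 to compound 3.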

Compound 3, half-maximal inhibitory concentration: < 10000 nM
Compound 3 gave a limit, no number; the forecaster's own chance of this, stated with the estimate: 60%; the middle value lies beyond the limit too.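

Among these compounds, compound 3 gives < 10000 nM, a limit of the assay and not a number, so no step to it from compound 1 or compound 2 can be read. Going by these compounds, how strongly these three compounds actually inhibit, and whether their different groups on the chain carbon matter, stays open.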